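A few compounds are considered here, and "the series" means these few. Any claim that something is new, unique, unknown or untested is made for them only; others in the source may bear on it.

Measured so far in a functional assay on P388D1 cells (Homo sapiens) for antiproliferative activity, read by sulforhodamine B assay, with a stated time of 48 h; on this read-out higher numbers stand for weaker inhibition and lower numbers for stronger inhibition:
- compound 1 `O=C1NCCN1c1ccc(S(=O)(=O)Nc2cccc(Br)c2)cc1`: 90 nM
- compound 2 `Cc1ccc(C)c(NS(=O)(=O)c2ccc(N3CCNC3=O)cc2)c1`: 79 nM

Compound 2 at 79 nM and compound 1 at 90 nM lie within the scatter of each other, so the two cannot be ranked.

The next compound is compound 3 `COc1cccc(NS(=O)(=O)c2ccc(N3CCNC3=O)cc2)c1`, with 3-methoxyphenyl in place of 2,5-dimethylphenyl on a sulfonamide nitrogen.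

Among the compounds with values here, only one measured step bears on this change: a 1.1-fold lower number from compound 1 to compound 2 (0.06 log units; within the scatter), where 2,5-dimethylphenyl replaced 3-bromophenyl at the same place. Within the data shown here, that step stays within the scatter, so the one swap seen at this nitrogen left the number in this assay unmoved. Among the measured compounds shown here, no measured compound carries the 3-methoxyphenyl group, and a single step is thin evidence, so the range has to stay wide. No step beyond the scatter is expected in this assay, with a slight lean towards a higher number at most. The estimated step is a 1.4-fold higher number from compound 2 to compound 3 (0.14 log units; within the scatter). For compound 3 the expected value is 110 nM, with an estimated range of 40 nM to 300 nM.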

Compound 3, half-maximal inhibitory concentration: 250 nM
Beside the measured number, compound 3's estimate is 2.3-fold (0.36 log units) below it, within the range that was stated.
By their numbers in this assay, from the lowest: compounds 2 and 1 (each within the scatter of the next); then compound 3.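

In this assay, the group on the sulfonamide nitrogen now proves able to move the number: 3-methoxyphenyl in place of 2,5-dimethylphenyl gives a 3.2-fold higher number from compound 2 to compound 3 (0.50 log units; beyond the scatter), and methoxy in place of bromo on an aromatic carbon gives a 2.8-fold higher number from compound 1 to compound 3 (0.44 log units; beyond the scatter), whereas the earlier swap at this nitrogen gave only a 1.1-fold lower number from compound 1 to compound 2 (0.06 log units; within the scatter). Both new steps are modest but point the same way, so compound 3 stands apart from compound 1 and compound 2, which remain within the scatter of each other and cannot be ranked. The change to compound 3 keeps the heavy-atom count of the group and adds one hydrogen-bond acceptor, but nothing available accounts for the higher number.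

With only three groups at this nitrogen, the compounds shown cannot say whether the shift belongs to methoxy itself or would also appear with a hydroxy, ethoxy or amino group on an aromatic carbon. They also leave open whether any group at this nitrogen gives a number clearly lower than those of compound 1 and compound 2.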